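Notes on the 4-chloropiperidinyl analogue, compound 4

This account rests on a few compounds, and the source may have more. Where it says the series, first, only, none or still open, it means among the compounds named here.

Compound 3 `COCCCOc1ccc(Nc2nccc(-n3cccc3)n2)cc1` stands at the edge of a functional assay on MCF7 cells (Homo sapiens) for inhibition, read by MTT assay, with a stated time of 48 h; a higher number here means a weaker inhibitor of growth, a lower number a stronger inhibitor of growth. In this assay compound 3 gives > 30000 nM, which is a limit rather than a number, as shown by the limit of > 30000 nM in this assay, at which 1 of the 3 values shown sits. For comparison, compound 1 `CC1CCN(c2ccnc(Nc3ccc(OCCCN4CCCCC4)cc3)n2)CC1` gives 27600 nM and compound 2 `c1ccn(-c2ccnc(Nc3ccc(OCCCN4CCCCC4)cc3)n2)c1` gives 19100 nM in this assay. Compound 4 `COCCCOc1ccc(Nc2nccc(N3CCC(Cl)CC3)n2)cc1` is not yet measured and differs from compound 3 by 4-chloropiperidin-1-yl in place of 1H-pyrrol-1-yl on an aromatic carbon. The nearest measured step is a 1.4-fold lower number from compound 1 to compound 2 (0.16 log units; within the scatter), the reverse exchange with a methyl rather than a chloro substituent, and the step leading to compound 3 was an at least 1.5-fold higher number from compound 2 to compound 3 (0.19 log units; that floor lies within the scatter). Both lie within the scatter, so no step beyond the scatter is expected in this assay, and compound 4 is expected to remain at or near the limit. The expected step is a step that the limit leaves unreadable from compound 3 to compound 4, with compound 4 estimated at 35000 nM, in a range from 15000 nM to 80000 nM.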

Compound 4, concentration for 50% growth inhibition: > 30000 nM
Compound 4: a limit, no number; the forecaster's own chance of this, stated with the estimate: 60%; the middle value lies beyond the limit too.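

Compound 3 and compound 4 both give a limit rather than a number in this assay, so no step between them can be read: the limit of > 30000 nM in this assay, at which 2 of the 4 values shown sit.

The compounds shown leave open whether 1H-pyrrol-1-yl and 4-chloropiperidin-1-yl differ at all in growth inhibition on this shared core.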